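The compounds below may be only part of what the source reports. "The series", "measured", "known", "first", "only" and "open" are said of these compounds alone.

Measured so far in a functional assay on K562 cells (Homo sapiens) for antiproliferative activity, read by MTT assay, with a stated time of 48 h; a higher number here means a weaker inhibitor, a lower number a stronger inhibitor:

compound 1 `Cc1nc2ccccc2nc1Oc1ccc(C(=O)N[C@@H](C)C(=O)O)cc1` gives 28100 nM
compound 2 `CC[C@@H](C)[C@H](NC(=O)c1ccc(Oc2nc3ccccc3nc2C)cc1)C(=O)O` gives 30500 nM
compound 3 `C[C@H](NC(=O)c1ccc(Oc2nc3ccccc3nc2NC(C)(C)C)cc1)C(=O)O` gives 26400 nM

All three numbers lie within the scatter of one another, so no order among them is claimed. Compound 1 to compound 2 carries the change sec-butyl in place of methyl on a saturated chain carbon bound to an amide-type nitrogen and a carbonyl carbon and shows a 1.1-fold higher number from compound 1 to compound 2 (0.04 log units; within the scatter). The two cores differ by (tert-butyl)amino in place of methyl on an aromatic carbon, with a 1.1-fold lower number from compound 1 to compound 3 (0.03 log units; within the scatter).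

Compound 4 `CC[C@@H](C)[C@H](NC(=O)c1ccc(Oc2nc3ccccc3nc2NC(C)(C)C)cc1)C(=O)O` is not yet measured. It differs from compound 3 by sec-butyl in place of methyl on a saturated chain carbon bound to an amide-type nitrogen and a carbonyl carbon, the same change already seen from compound 1 to compound 2, at a place described in the same words. Since that earlier step stayed within the scatter, the step for compound 4 is expected to be a 1.1-fold higher number from compound 3 to compound 4 (0.03 log units; within the scatter), resting on a 1.1-fold higher number from compound 1 to compound 2 (0.04 log units; within the scatter) applied to compound 3. Compound 4 is therefore estimated at 28500 nM in this assay, expected between 14000 nM and 57000 nM.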

Compound 4, half-maximal inhibitory concentration: 18300 nM
Estimate against measurement, compound 4: 1.6-fold (0.19 log units) above; measured number inside the range.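

In this assay the change of methyl to sec-butyl on a saturated chain carbon bound to an amide-type nitrogen and a carbonyl carbon gives a 1.4-fold lower number from compound 3 to compound 4 (0.16 log units; within the scatter), and the two cores cannot be told apart for this change: the same change on two cores in this assay, a 1.1-fold higher number (0.04 log units; within the scatter) from compound 1 to compound 2 and a 1.4-fold lower number (0.16 log units; within the scatter) from compound 3 to compound 4, 1.6-fold (0.19 log units) apart, within the scatter of two such steps. The change of methyl to (tert-butyl)amino on an aromatic carbon, read with sec-butyl in place, gives a 1.7-fold lower number from compound 2 to compound 4 (0.22 log units; within the scatter), and it also carries over within the scatter: the same change on two cores in this assay, a 1.1-fold lower number (0.03 log units; within the scatter) from compound 1 to compound 3 and a 1.7-fold lower number (0.22 log units; within the scatter) from compound 2 to compound 4, 1.6-fold (0.19 log units) apart, within the scatter of two such steps. This shows that neither change moves the number beyond the scatter on these cores, but it does not establish a real effect of either change or show that the same would hold on any other core.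

Open, going by these compounds, is whether a benzyl group or a longer chain in place of sec-butyl would move the number beyond the scatter. Also open, on these data alone, is what a methyl ester or a primary amide in place of the carboxylic acid would do.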